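Three Measured Triazoles and One Still Untested

The source may report more compounds than this note shows. Statements on the series, on what has been measured and on what is new or still open speak of the compounds shown alone.

Three compounds built on one shared core were tested in a functional assay on PC-12 cells (Rattus norvegicus) for cytotoxicity, read by MTT assay, with stated times of 2 h and 24 h, tested at 5 uM; a lower number here means a weaker effect, a higher number a stronger effect of the compound at the concentration tested. Compound 1 `Oc1cc(C(F)(F)F)ccc1-c1nc(-c2ccccc2O)n(-c2ccc(Cl)cc2)n1` gives 87.3% in this assay. Compound 2 `Oc1cc(C(F)(F)F)ccc1-c1nc(-c2ccccc2O)n(-c2ccc(C(F)(F)F)cc2)n1` gives 90.5%. Compound 3 `Oc1cc(C(F)(F)F)ccc1-c1nc(-c2ccccc2O)n(-c2ccccc2Cl)n1` gives 90.6%. The change trifluoromethyl in place of chloro on an aromatic carbon made a step of a number 3.2 percentage points higher from compound 1 to compound 2 (within the scatter). The two cores of compound 1 and compound 3 differ by 2-chlorophenyl in place of 4-chlorophenyl on an aromatic nitrogen, and that change made a step of a number 3.3 percentage points higher from compound 1 to compound 3 (within the scatter). Between compound 2 and compound 3 the step was a number 0.1 percentage points higher from compound 2 to compound 3 (within the scatter). Going by the values given here, all three numbers lie within the scatter of one another, so no compound can be set above another.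

Compound 4 `Oc1cc(C(F)(F)F)ccc1-c1nc(-c2ccccc2O)n(-c2ccccc2C(F)(F)F)n1` has not yet been measured. It differs from compound 3 by trifluoromethyl in place of chloro on an aromatic carbon. This is the same kind of change as that made from compound 1 to compound 2, though not the same: in compound 4 the entering group sits ortho to a large group, whereas in compound 2 it sits para to a large group. The earlier step of this kind, a number 3.2 percentage points higher from compound 1 to compound 2 (within the scatter), stayed within the scatter. Beside it, the expected step in this assay is a number 0.1 percentage points lower from compound 3 to compound 4 (within the scatter). Compound 4 is therefore estimated at 90.5%, with a range from 83% to 97%.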

Compound 4, a percentage reported as activity, at one concentration (the size of the read-out at that concentration, not a potency): 80%
Compound 4: the middle estimate sits 10.5 percentage points above what was measured; the measured number lies below the stated range.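

In this assay, trifluoromethyl in place of chloro gave a number 10.6 percentage points lower from compound 3 to compound 4 (beyond the scatter), 2-(trifluoromethyl)phenyl in place of 4-(trifluoromethyl)phenyl gave a number 10.5 percentage points lower from compound 2 to compound 4 (beyond the scatter), and 2-(trifluoromethyl)phenyl in place of 4-chlorophenyl gave a number 7.3 percentage points lower from compound 1 to compound 4 (within the scatter). The same exchange of chloro for trifluoromethyl has now been seen on two cores, and its two steps point in opposite directions, yet they cannot be told apart: the same change on two cores in this assay, a number 3.2 percentage points higher (within the scatter) from compound 1 to compound 2 and a number 10.6 percentage points lower (beyond the scatter) from compound 3 to compound 4, 13.8 percentage points apart, within the scatter of two such steps. This pair therefore neither shows that the change carries from one core to another in this series nor that it fails to, and it gives no reason for the result.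

The compounds shown leave open how other groups on this aromatic ring would read in this assay, for example a methoxy group, an amine or a carboxylic acid in place of chloro or trifluoromethyl. They also leave open what would follow if either hydroxyl group of the shared core gave way to a methoxy group or an amine.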